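Solubility Expected for a Carboxythiophene Analogue

This account rests on a few compounds, and the source may have more. Where it says the series, first, only, none or still open, it means among the compounds named here.

Measured in a physicochemical assay for solubility, in phosphate buffer, with a stated time of 18 h; on this read-out lower numbers stand for lower solubility and higher numbers for higher solubility:
Compound 1 `CC(C)(C)c1ccc2c(N)c(C#N)c(N)nc2n1` gives 14200 nM
Compound 2 `N#Cc1c(N)nc2nc(C3CCC3)ncc2c1N` gives 217000 nM
Compound 3 `CCCCc1nc(C(C)(C)C)nc2nc(N)c(C#N)c(N)c12` gives 6000 nM

Among these three values compound 3 stands lowest: compound 1 is nearest to it, with a gap beyond the scatter, and compound 2 is furthest, with a gap well beyond it. Compound 4 `CC(C)(C)c1nc(-c2ccc(C(=O)O)s2)c2c(N)c(C#N)c(N)nc2n1` has not yet been measured in this assay. It differs from compound 3 in one place: 5-carboxythiophen-2-yl in place of butyl on an aromatic carbon. The entering group carries one hydrogen-bond donor and two hydrogen-bond acceptors where the butyl carried none. Going by the values given here, no measured pair shows this change, so the direction rests on expectation alone. Compound 4 is expected to give a higher number than compound 3, a step of a 10-fold higher number from compound 3 to compound 4 (1.00 log units; beyond the scatter) beyond the scatter. The estimate for compound 4 is 60000 nM, within 12000 nM to 300000 nM.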

Compound 4, solubility: > 1000000 nM
Compound 4: a limit, no number (the forecaster's own chance of this, stated with the estimate: 5%); at least 16-fold (1.22 log units) between middle value and limit.
By their numbers in this assay, from the lowest: compound 3; then compound 1; then compound 2. At a limit, above all of these: compound 4.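

In this assay, 5-carboxythiophen-2-yl in place of butyl on this aromatic carbon gives an at least 160-fold higher number from compound 3 to compound 4 (2.22 log units; beyond the scatter), a large step and the only one that can be read among these compounds. On these data alone, compound 4 gives > 1000000 nM, which is a limit of the assay and not a number, so the full size of the step stays unknown. Going by these compounds alone, the earlier compounds held no step, so this is the first sign that the group at this position can move the read-out.

The compounds shown leave open which part of the entering group carries the step. A plain thiophene, a methyl ester or a carboxylic acid on an open chain at this position could separate these parts.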